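This account rests on a few compounds, and the source may have more. Where it says the series, first, only, none or still open, it means among the compounds named here.

In a functional assay on HepG2 cells (Homo sapiens) for inhibition, read by MTT assay, with a stated time of 24 h (on this read-out higher numbers stand for weaker inhibition and lower numbers for stronger inhibition), compound 1 `COc1ccccc1-n1cc(CN2C(=O)C[C@@H]3CC[C@@]2(C)C3(C)C)nn1` gives 110 nM, compound 2 `CC1(C)[C@H]2CC[C@]1(C)N(Cc1cn(-c3ccc(O)cc3)nn1)C(=O)C2` gives 80 nM and compound 3 `CC1(C)[C@H]2CC[C@]1(C)N(Cc1cn(-c3cccc(O)c3)nn1)C(=O)C2` gives 70 nM. Compound 3 stands within the scatter of both others. The steps read a 1.1-fold lower number from compound 2 to compound 3 (0.06 log units; within the scatter), a 1.6-fold lower number from compound 1 to compound 3 (0.20 log units; within the scatter) and a 1.4-fold lower number from compound 1 to compound 2 (0.14 log units; within the scatter). Compound 4 `COc1ccc(-n2cc(CN3C(=O)C[C@@H]4CC[C@@]3(C)C4(C)C)nn2)cc1` keeps the shared core and alters only the group on the aromatic nitrogen: 4-methoxyphenyl in place of 3-hydroxyphenyl on an aromatic nitrogen. All three measured steps changed that same group and none left the scatter, so no step beyond the scatter is expected in this assay. The step expected here is a 1.3-fold higher number from compound 3 to compound 4 (0.11 log units; within the scatter). Compound 4 is estimated at 90 nM, with an expected range of 45 nM to 180 nM.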

Compound 4, half-maximal inhibitory concentration: 100 nM
For compound 4 the middle estimate is 1.1-fold (0.05 log units) below the measured one; measured number inside the range.
By their numbers in this assay, from the lowest: compounds 3, 2, 4 and 1 (each within the scatter of the next).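

In this assay, methyl in place of hydrogen on the oxygen gives a 1.3-fold higher number from compound 2 to compound 4 (0.10 log units; within the scatter), so 4-methoxyphenyl, with no hydrogen-bond donor, reads level with 4-hydroxyphenyl, which has one. Moving the methoxy group gives a 1.1-fold lower number from compound 1 to compound 4 (0.04 log units; within the scatter), and the change from 3-hydroxyphenyl gives a 1.4-fold higher number from compound 3 to compound 4 (0.15 log units; within the scatter), so neither the donor nor the methoxy placement shifts these compounds beyond the scatter. Nothing available explains why these groups read alike.

Still open, from the compounds shown here alone, is whether an amine or a carboxylic acid on the phenyl ring, or a longer chain in place of the methyl, would move the number beyond the scatter.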